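A tert-Butyl Group Set Against Two Isomeric Cores

The compounds below may be only part of what the source reports. "The series", "measured", "known", "first", "only" and "open" are said of these compounds alone.

Compound 1 `CCOC(=O)c1c(-c2ccccc2)[nH]c2cc(OC)ccc2c1=O` and compound 3 `CCOC(=O)c1c(-c2ccccc2)[nH]c2cccc(OC)c2c1=O` are built from the same atoms joined differently; the difference between the two cores is not broken down here. In a physicochemical assay for solubility, in phosphate buffer, at pH 7.4 (a higher number here means a more soluble compound, a lower number a less soluble compound), compound 1 gives > 100000 nM, which is a limit of the assay and not a number. In this assay compound 3 also gives > 100000 nM, again a limit. Both rest at the limit of > 100000 nM in this assay, at which 2 of the 3 values shown sit. Compound 2 `CCOC(=O)c1c(-c2ccc(C(C)(C)C)cc2)[nH]c2cccc(OC)c2c1=O` differs from compound 3 by tert-butyl in place of hydrogen on an aromatic carbon and in this assay compound 2 gives 1000 nM; the step is an at least 100-fold lower number from compound 3 to compound 2 (2.00 log units; beyond the scatter). Compound 4 `CCOC(=O)c1c(-c2ccc(C(C)(C)C)cc2)[nH]c2cc(OC)ccc2c1=O` makes the same change on the core of compound 1, namely (tert-butyl in place of hydrogen on an aromatic carbon). Given an at least 100-fold lower number from compound 3 to compound 2 (2.00 log units; beyond the scatter), the step expected here is an at least 100-fold lower number from compound 1 to compound 4 (2.00 log units; beyond the scatter). Compound 4 is therefore estimated at 1000 nM, most likely between 250 nM and 5000 nM.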

Compound 4, solubility: 2000 nM
For compound 4 the middle estimate is 2.0-fold (0.30 log units) below the measured one; low and high end bracket the measured number.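

On the core of compound 1, tert-butyl in place of hydrogen on an aromatic carbon again gives a large change in this assay with an at least 50-fold lower number from compound 1 to compound 4 (1.69 log units; beyond the scatter) in the same direction as an at least 100-fold lower number from compound 3 to compound 2 (2.00 log units; beyond the scatter) on the other core. The change thus carried over between these two cores in direction and in lying beyond the scatter. Both steps start from a limit of the assay and not from a number, so neither gives a true size, and two cores make no general rule.

The compounds shown leave open whether an amine or a carboxylic acid in the same place would move the number the other way. On these data alone, what tert-butyl does on any further core also stays open.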